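Methoxy to ethoxy on the aryl group

A few compounds are considered here, and "the series" means these few. Any claim that something is new, unique, unknown or untested is made for them only; others in the source may bear on it.

- compound 1 `CNc1nc(-c2cc(OC)c(OC)c(OC)c2)c(-c2ccc(C)cc2)s1` gives 18.1 nM in a functional assay on HL-60 cells (Homo sapiens) for antiproliferative activity, read by MTT assay, with a stated time of 72 h; a higher number here means a weaker inhibitor, a lower number a stronger inhibitor
- compound 2 `CNc1nc(-c2cc(OC)c(OC)c(OC)c2)c(-c2ccc(OC)cc2)s1` gives 27.3 nM in this assay

The values of compound 2 and compound 1 lie within the scatter of each other, so the two do not separate. Compound 3 `CCOc1ccc(-c2sc(NC)nc2-c2cc(OC)c(OC)c(OC)c2)cc1` replaces the 4-methoxyphenyl of compound 2 with 4-ethoxyphenyl: methyl in place of hydrogen on a saturated chain carbon bound to an oxygen on an aromatic ring. Among the compounds with values here, only one measured step bears on this, a 1.5-fold higher number from compound 1 to compound 2 (0.18 log units; within the scatter), where methoxy takes the place of methyl on an aromatic carbon. It is a different change and a loose guide. No step beyond the scatter is therefore expected in this assay and no firm direction. The expected step is a 1.2-fold higher number from compound 2 to compound 3 (0.07 log units; within the scatter) and remains small. Compound 3 is estimated at 32 nM, with an expected range from 13 nM to 80 nM in this series.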

Compound 3, half-maximal inhibitory concentration: 1.8 nM
Compound 3: middle estimate off by 18-fold (1.25 log units), on the high side; the whole stated range lies above it.
By their numbers in this assay, from the lowest: compound 3; then compounds 1 and 2 (each within the scatter of the next).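

In this assay the 4-ethoxyphenyl group separates from both earlier groups: one added methyl on the saturated chain carbon bound to the oxygen gives a 15-fold lower number from compound 2 to compound 3 (1.18 log units; beyond the scatter) and so goes beyond the scatter, which the exchange of methyl for methoxy on the aromatic carbon did not. Against the methyl of compound 1, the ethoxy group gives a 10-fold lower number from compound 1 to compound 3 (1.00 log units; beyond the scatter) in the same direction, so among these three compounds an oxygen alone does not separate from methyl, while methoxy to ethoxy does. No evidence at hand accounts for this gain.

As far as these compounds go, whether the gain continues with a propoxy or longer chain on the oxygen remains open. Also open, from the compounds shown here alone, is how a branched isopropoxy group or a ring-bearing benzyloxy group would behave at this place.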